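From cyclopropylmethyl amide to primary amide

The compounds below may be only part of what the source reports. "The series", "measured", "known", "first", "only" and "open" are said of these compounds alone.

In a functional assay (muscle tissue) with Rattus norvegicus as the target (a lower number here means that less compound is needed, a higher number that more compound is needed for the effect), compound 1 (`CCNC(=O)C1=CC(C)(C)Oc2ccc([N+](=O)[O-])cc21`) gives 4.57 nM, compound 2 (`CCCCNC(=O)C1=CC(C)(C)Oc2ccc([N+](=O)[O-])cc21`) gives 21.9 nM and compound 3 (`CC1(C)C=C(C(=O)NCC2CC2)c2cc([N+](=O)[O-])ccc2O1`) gives 6.61 nM. The number for compound 3 cannot be separated from that of compound 1: a 1.4-fold higher number from compound 1 to compound 3 (0.16 log units; within the scatter). Two steps lie beyond the scatter: a 4.8-fold higher number from compound 1 to compound 2 (0.68 log units; beyond the scatter) and a 3.3-fold lower number from compound 2 to compound 3 (0.52 log units; beyond the scatter).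

Compound 4 (`CC1(C)C=C(C(N)=O)c2cc([N+](=O)[O-])ccc2O1`) is reached from compound 3 by hydrogen in place of cyclopropylmethyl on an amide-type nitrogen. Going by the values given here, no measured step removes the whole substituent, so the three steps above give only indirect guidance, and the largest is modest. No step beyond the scatter is expected, with a slight lean towards a higher number. The estimated step is a 1.5-fold higher number from compound 3 to compound 4 (0.18 log units; within the scatter). For compound 4 the expected value is 10 nM, with an estimated range of 2.5 nM to 40 nM.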

Compound 4, half-maximal effective concentration: 363 nM
Compound 4: middle estimate off by 36-fold (1.56 log units), on the low side; the whole stated range lies below it.
By their numbers in this assay, from the lowest: compounds 1 and 3 (each within the scatter of the next); then compound 2; then compound 4.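

Some substituent on the amide-type nitrogen matters far more in this assay than the differences among ethyl, butyl and cyclopropylmethyl: hydrogen in its place gives the largest steps in the series (a 55-fold higher number from compound 3 to compound 4 (1.74 log units; beyond the scatter)) (a 17-fold higher number from compound 2 to compound 4 (1.22 log units; beyond the scatter)) (a 79-fold higher number from compound 1 to compound 4 (1.90 log units; beyond the scatter)). All three substituted amides lie on the same side of the primary amide, and none goes against this, so even butyl, the weakest of them, keeps most of the effect. On these data alone, whether methyl alone on that nitrogen is enough, and how a chain longer than butyl behaves, stays open. Nothing measured here accounts for the jump.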